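The source may hold more compounds than are shown below. What is called first, only, known or untested is meant among the compounds shown, and "the series" means these compounds.

In a physicochemical assay for pharmacokinetics, at pH 6 (on this read-out lower numbers stand for a shorter-lived compound and higher numbers for a longer-lived compound), compound 1 (`CC(C)OC[C@H](Oc1ncnc2c1cnn2-c1ncccc1Cl)C(=O)Nc1ccc(Cl)cn1`) gives > 552 h as a limit, not a number. Compound 2 (`CC(C)OC[C@H](Oc1ncnc2c1cnn2-c1ncccc1Cl)C(=O)Nc1ccc(F)cn1`) stands at > 552 h and that too is only a limit. The evidence on this read-out so far comes to the limit of > 552 h in this assay, at which 2 of the 2 values shown sit, and no more.

Compound 3 (`CC(C)OC[C@H](Oc1ncnc2c1cnn2-c1ncccc1Cl)C(=O)Nc1ccc(C#N)cn1`) carries cyano in place of fluoro on an aromatic carbon, two atoms from the ring nitrogen and para to a large group (cyano in place of fluoro on an aromatic carbon). Within the data shown here, the one measured step that bears on this is a step that the two limits leave unreadable from compound 1 to compound 2 with fluoro in place of chloro, and it offers no size to carry over. No step beyond the scatter, in either direction, is therefore expected in this assay here. The expected step is (a step that the limit leaves unreadable from compound 2 to compound 3). A further report as a limit is the likeliest outcome. For compound 3 the estimate is 600 h (expected range 350 h to 1000 h).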

Compound 3, half-life: > 552 h
Compound 3 was reported as a limit; the forecaster's own chance of this, stated with the estimate: 80%; the middle value lies beyond the limit too.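

Compound 1, compound 2 and compound 3 are all reported only as limits, so no step among them can be read in this assay: the limit of > 552 h in this assay, at which 3 of the 3 values shown sit.

The compounds shown leave open whether chloro, fluoro and cyano differ at all on this read-out.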